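The source may report more compounds than this note shows. Statements on the series, on what has been measured and on what is new or still open speak of the compounds shown alone.

Measured so far:
compound 1 `O=C1NC(=O)N(/N=C/c2ccc(-c3ccc(Cl)cc3)o2)C1O`: 63 mg/kg
compound 2 `O=C1NC(=O)N(/N=C/c2ccc(-c3ccc(Cl)c(Cl)c3)o2)C1O`: 10 mg/kg

In an ADME assay on the whole organism (muscle tissue) for activation, with Mus musculus as the target, in the rotarod test, with a stated time of 30 min (on this read-out higher numbers stand for an effect only at larger amounts of compound and lower numbers for an effect already at smaller amounts), compound 1 gives 63 mg/kg, the higher of the two numbers. For the measured compounds named here, the one measured step, a 6.3-fold lower number from compound 1 to compound 2 (0.80 log units; beyond the scatter), comes from a chloro added at a second position and so has no direct bearing on the change considered here.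

Compound 3 `O=C1NC(=O)N(/N=C/c2ccc(-c3ccc(F)cc3)o2)C1O` differs from compound 1 by fluoro in place of chloro on an aromatic carbon. Going by the values given here, with no comparable step measured, the expected change in this assay is none beyond the scatter, at most a slightly higher number, so the expected step is a 1.3-fold higher number from compound 1 to compound 3 (0.10 log units; within the scatter). Compound 3 is therefore estimated at 80 mg/kg, within a range from 35 mg/kg to 180 mg/kg.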

Compound 3, dose for half-maximal effect: 240 mg/kg
For compound 3 the middle estimate is 3.0-fold (0.48 log units) below the measured one; measured number outside the range, above it.
By their numbers in this assay, from the lowest: compound 2; then compound 1; then compound 3.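

Notes on the series: in this assay, the halogen at this position is not interchangeable, since going from 4-chlorophenyl to 4-fluorophenyl raises the number (a 3.8-fold higher number from compound 1 to compound 3 (0.58 log units; beyond the scatter)). The earlier step showed only the effect of adding a second chloro, whereas this one shows that exchanging the existing halogen alone also moves the dose beyond the scatter, with chloro the better of the two. Nothing available explains this difference.

Open, on these data alone, is how bromo, methyl, methoxy or an amine would behave at this position. Also open, as far as these compounds go, is whether fluoro would hold up alongside the second chloro of compound 2.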